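A second chlorine on the pendant ring of compound 1

A few compounds are considered here, and "the series" means these few. Any claim that something is new, unique, unknown or untested is made for them only; others in the source may bear on it.

Compound 1 `Cn1cncc1C(OCc1ccc(C#N)cc1-c1cccc(Cl)c1)c1ccc(C#N)nc1` was tested in a functional assay on NIH3T3 cells (Mus musculus) (a lower number here means that less compound is needed, a higher number that more compound is needed for the effect), where compound 1 gives 2.1 nM. Two relatives share the same two nitrile groups and the same chlorine-bearing ring but carry a saturated ring on the core: compound 2 `Cn1cncc1C(OCc1nc(N2CCC(C(N)=O)CC2)c(C#N)cc1-c1cccc(Cl)c1)c1ccc(C#N)cc1` gives 1.5 nM, and compound 3 `Cn1cncc1C(OCc1nc(N2CCC(O)CC2)c(C#N)cc1-c1cccc(Cl)c1)c1ccc(C#N)cc1` gives 3.6 nM. Within the data shown here, the only measured step is a 2.4-fold higher number from compound 2 to compound 3 (0.38 log units; beyond the scatter), which concerns hydroxy in place of carbamoyl on a saturated ring carbon. Compound 1 sits between compound 2 and compound 3, and its gap to each of them lies within the usual scatter.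

The untested compound 4 `Cn1cncc1C(OCc1ccc(C#N)cc1-c1cc(Cl)cc(Cl)c1)c1ccc(C#N)nc1` differs from compound 1 by chloro in place of hydrogen on an aromatic carbon. Read one bond further out, the change is 3-chlorophenyl to 3,5-dichlorophenyl. Among the measured compounds shown here, no measured step touches this ring; the one known step, from a carbamoyl to a hydroxy group on a saturated ring, says nothing about adding a chlorine to an aromatic ring. The data therefore give no reason to expect a step beyond the scatter in either direction. Compound 4 is expected to give 2.3 nM, within a range from 0.8 nM to 7 nM. This estimate amounts to a 1.1-fold higher number from compound 1 to compound 4 (0.04 log units; within the scatter).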

Compound 4, half-maximal effective concentration: 3.5 nM
For compound 4 the middle estimate is 1.5-fold (0.18 log units) below the measured one, and the stated range covers the measured number.
By their numbers in this assay, from the lowest: compounds 2, 1, 4 and 3 (each within the scatter of the next, the first and the last beyond it).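

Going from 3-chlorophenyl to 3,5-dichlorophenyl is the first change on the pendant ring that can be read directly, and this assay records it as a 1.7-fold higher number from compound 1 to compound 4 (0.22 log units; within the scatter) without showing a real difference. The earlier compounds shown here varied only a group on the saturated ring, so they said nothing about this aromatic carbon; now it is clear that a chloro group can take the place of hydrogen here, meta to the first chloro group, without a step that stands out from repeat-to-repeat variation. Nothing available explains this outcome or indicates what the added chlorine does at this position.

The compounds shown leave open whether a different group on the same carbon, such as fluoro, methoxy, an amine or a carboxylic acid, would produce a step beyond the scatter, and thus how much this position can really accommodate. As far as these compounds go, it also remains open whether 3,5-dichlorophenyl would give a similarly small step on the core of compound 2 or compound 3, both of which carry a saturated ring.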